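Compound 4: isopropyl in place of 4-carbamoylcyclohexyl

The source may hold more compounds than are shown below. What is called first, only, known or untested is meant among the compounds shown, and "the series" means these compounds.

Among the compounds with values here, in an ADME assay on Caco-2 cells (Homo sapiens) for permeability, in the apical to basolateral direction (a lower number here means that the compound crosses the layer more slowly, a higher number that the compound crosses the layer faster), compound 1 `COC(=O)N1CCN([C@H]2CC[C@H](Nc3ncnn4ccc([C@H](C)CC(=O)N(C)C)c34)CC2)CC1` gives 18 10^-6 cm/s, the only true number so far. Compound 2 `CC(=O)N1CCN([C@H]2CC[C@H](Nc3ncnn4ccc([C@H]5CC[C@H](C(N)=O)CC5)c34)CC2)CC1` gives < 0.7 10^-6 cm/s, which is a limit of the assay and not a number. Compound 3 `CN(C)[C@H]1CC[C@H](Nc2ncnc3[nH]cc([C@H]4CC[C@H](C(N)=O)CC4)c23)CC1` gives < 0.2 10^-6 cm/s, also a limit. Compound 2 therefore stands at a limit rather than at a measured value, and both compounds at a limit carry 4-carbamoylcyclohexyl.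

Compound 4 `CC(=O)N1CCN([C@H]2CC[C@H](Nc3ncnn4ccc(C(C)C)c34)CC2)CC1` keeps the rest of compound 2 but has isopropyl in place of 4-carbamoylcyclohexyl on an aromatic carbon. Within the data shown here, no measured step isolates this change, so the expectation rests on three compounds only. It leans on compound 1, which lacks 4-carbamoylcyclohexyl and gives 18 10^-6 cm/s. An upward change beyond the scatter is expected, and the estimated step is an at least 17-fold higher number from compound 2 to compound 4 (1.23 log units; beyond the scatter). For compound 4 the estimate is 12 10^-6 cm/s, with an expected range of 3 10^-6 cm/s to 30 10^-6 cm/s.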

Compound 4, apparent permeability: 38 10^-6 cm/s
Estimate against measurement, compound 4: 3.2-fold (0.50 log units) below, outside the stated range (above it).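

This position on the aromatic carbon of the five-membered ring now has its first comparison in one place in this assay, with an at least 54-fold higher number from compound 2 to compound 4 (1.73 log units; beyond the scatter). Compound 2 sits at a limit of the assay, so the step has a floor and no exact size: the limit of < 0.7 10^-6 cm/s in this assay, at which 1 of the 4 values shown sits. Compound 4 gives a true number, 38 10^-6 cm/s, showing that the rest of compound 2 can reach a measurable value once 4-carbamoylcyclohexyl gives way to isopropyl.

The change removes the carbon ring, the double bond outside aromatic rings, the hydrogen-bond donor and the hydrogen-bond acceptor all at once, and the compounds shown do not separate these features. Plain cyclohexyl, or a carboxylic acid or primary amine on a short chain at this position, remains open in this series.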